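This account rests on a few compounds, and the source may have more. Where it says the series, first, only, none or still open, it means among the compounds named here.

Measured so far in a functional assay on MCF7 cells (Homo sapiens) for inhibition; a higher number here means a weaker inhibitor, a lower number a stronger inhibitor:
compound 1 `CC/C(=C(/c1ccc(/C=C/C(=O)O)cc1)c1cc2ccccc2[nH]1)c1ccccc1Cl` gives 42 nM
compound 2 `CC/C(=C(/c1ccc(/C=C/C(=O)O)cc1)c1cc2ccccc2[nH]1)c1cccc(C(F)(F)F)c1` gives 325 nM

Compound 1 stands lowest of the two numbers in this assay; its nearest neighbour is compound 2, reached by a 7.7-fold higher number from compound 1 to compound 2 (0.89 log units; beyond the scatter). Compound 3 `CC/C(=C(/c1ccc(/C=C/C(=O)O)cc1)c1cc2ccccc2[nH]1)c1ccc(OC)cc1` differs from compound 1 as follows: 4-methoxyphenyl in place of 2-chlorophenyl on a double-bonded chain carbon bound to a double-bonded chain carbon and a saturated chain carbon. Within the data shown here, the one measured step bears on this only loosely, since it replaces the same 2-chlorophenyl group with a different aryl group, and it gave a modestly higher number. As far as these compounds go, a rise of similar or smaller size is therefore expected for compound 3, though the new group is untested and the uncertainty is wide. Compound 3 is expected to give 120 nM in this assay, within 35 nM to 450 nM, a step of a 2.9-fold higher number from compound 1 to compound 3 (0.46 log units; beyond the scatter).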

Compound 3, half-maximal inhibitory concentration: 61 nM
Compound 3: the middle estimate sits 2.0-fold (0.29 log units) above what was measured; the range from low to high includes it.
By their numbers in this assay, from the lowest: compounds 1 and 3 (each within the scatter of the next); then compound 2.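

In this assay, 4-methoxyphenyl on this double-bonded chain carbon matches 2-chlorophenyl within the scatter (a 1.5-fold higher number from compound 1 to compound 3 (0.16 log units; within the scatter)), so a chlorine is not required for a low number. The 3-(trifluoromethyl)phenyl group stands apart from 4-methoxyphenyl (a 5.3-fold lower number from compound 2 to compound 3 (0.73 log units; beyond the scatter)), so the higher number of compound 2 does not reflect every change away from 2-chlorophenyl. No evidence on the origin of these differences is available. The three aryl groups differ in both substituent and substitution pattern, so these two variables remain unseparated. As far as these compounds go, how an amine or a hydroxyl group on the phenyl ring would fare remains open.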